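The source may report more compounds than this note shows. Statements on the series, on what has been measured and on what is new or still open speak of the compounds shown alone.

Compound 1 `O=C(CCCCCNc1c(NCc2ccccc2)c(=O)c1=O)NO`: 5700000 nM
Compound 2 `Cc1ccccc1Nc1c(NCCCCCC(=O)NO)c(=O)c1=O`: 12000000 nM
Compound 3 `Cc1ccc(Nc2c(NCCCCCC(=O)NO)c(=O)c2=O)cc1`: 1800000 nM

These three numbers all come from a physicochemical assay for solubility, with a stated time of 24 h, tested at 30 mg/mL; on this read-out lower numbers stand for lower solubility and higher numbers for higher solubility. Compound 3 has the lowest of them, at 1800000 nM, and both of the other compounds lie beyond the scatter from it.

The next compound, compound 4 `COc1ccc(Nc2c(NCCCCCC(=O)NO)c(=O)c2=O)cc1`, has not yet been measured. It differs from compound 3 in a single place: methoxy in place of methyl on an aromatic carbon. In words, this is methoxy in place of methyl on an aromatic carbon, so 4-methylphenyl becomes 4-methoxyphenyl.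

Going by the values given here, no measured step makes this exact change. The nearest evidence comes from the two steps that end at compound 3, each of which changes the group on a nitrogen. Putting 4-methylphenyl in place of 2-methylphenyl gave a 6.7-fold lower number from compound 2 to compound 3 (0.82 log units; beyond the scatter), and putting 4-methylphenyl in place of benzyl gave a 3.2-fold lower number from compound 1 to compound 3 (0.50 log units; beyond the scatter). Both steps were modest, and neither shows which way a methoxy would move the number. Only a small step is therefore expected in this assay, with a slight upward lean given the low place of compound 3 at 1800000 nM.

The expected step is a 1.4-fold higher number from compound 3 to compound 4 (0.14 log units; within the scatter).

For compound 4 the estimated value is 2500000 nM, with an expected range from 800000 nM to 7000000 nM.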

Compound 4, solubility: 300000 nM
For compound 4 the middle estimate is 8.3-fold (0.92 log units) above the measured one, outside the stated range (below it).
By their numbers in this assay, from the lowest: compound 4; then compound 3; then compound 1; then compound 2.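

In this assay, the aromatic carbon para to a large group proves to be a place where a small swap matters: methoxy in place of methyl, which adds one oxygen and one hydrogen-bond acceptor, gave a 6.0-fold lower number from compound 3 to compound 4 (0.78 log units; beyond the scatter). The earlier steps shown here all changed the group on the nitrogen, so they could not show that a change on the ring itself, with the rest of compound 3 held fixed, moves this number beyond the scatter. Going by these compounds alone, the 4-methoxyphenyl group also gives the first large steps in the set, a 40-fold lower number from compound 2 to compound 4 (1.60 log units; beyond the scatter) and a 19-fold lower number from compound 1 to compound 4 (1.28 log units; beyond the scatter), leaving compound 4 lowest of the four, whereas every step among the first three compounds was modest.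

Nothing available here explains why the number falls with this change. Going by these compounds, it remains open whether this drop is particular to methoxy or would also appear with another group on the same carbon, such as a hydroxyl, an amine or a carboxylic acid, and a single methyl-to-methoxy pair cannot show how far the result extends to other compounds.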